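The source may hold more compounds than are shown below. What is called first, only, known or untested is meant among the compounds shown, and "the series" means these compounds.

Measured so far:
Compound 1 `Nc1[nH]c(C(=O)c2ccccc2)c(-c2cccc(Cl)c2)c1C(=O)c1cccc(Cl)c1`; in an assay for inhibition of Polyunsaturated fatty acid lipoxygenase ALOX15 (Homo sapiens), with a stated time of 10 min (on this read-out lower numbers stand for stronger inhibition and higher numbers for weaker inhibition), compound 1 gives > 100000 nM, which is a limit of the assay.
Compound 2 `NC(=O)c1c(N)[nH]c(C(=O)c2ccccc2)c1-c1ccc(Cl)cc1Cl`; in this assay compound 2 gives > 100000 nM, likewise a limit of the assay.

Within the data shown here, compound 2 thus stands at a limit, not at a number, and the one further value, that of compound 1, is a limit as well (the limit of > 100000 nM in this assay, at which 2 of the 2 values shown sit). Among the measured compounds shown here, no pair of measured compounds differs in one place, so no measured step shows how far a single change moves this read-out.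

Compound 3 `Nc1[nH]c(C(=O)c2ccccc2)c(-c2ccc(Cl)cc2Cl)c1C(=O)c1cccc(F)c1` is not yet measured. It differs from compound 2 in one place: 3-fluorophenyl in place of amino on a carbonyl carbon. Cut one bond further out, the change reads carbamoyl to (3-fluorophenyl)carbonyl. Compound 1 already carries two aryl carbonyl groups on the shared core and sits at the limit, and compound 3 carries two as well.

No step beyond the scatter is expected from compound 2 to compound 3, and a limit rather than a number is the likely outcome: a number no higher from compound 2 to compound 3 (the limit leaves the size open). Compound 3 is estimated at 100000 nM, within 20000 nM to 400000 nM.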

Compound 3, half-maximal inhibitory concentration: > 100000 nM
Compound 3 gave a limit, no number (the forecaster's own chance of this, stated with the estimate: 80%); the middle value sits exactly at the limit.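

No step can be read between compound 2 and compound 3, because both values in this assay are limits of the assay and not numbers: the limit of > 100000 nM in this assay, at which 3 of the 3 values shown sit.

The compounds shown leave open whether any change on the shared core brings the half-maximal inhibitory concentration to a measurable number, and how the three compare with one another.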